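Adding a Third Methoxy to an Inactive Triazole Amide

This account rests on a few compounds, and the source may have more. Where it says the series, first, only, none or still open, it means among the compounds named here.

Compound 2 `COc1ccc(-c2nn(-c3ccccc3)cc2C(=O)NCc2cn(Cc3ccc(OC)c(OC)c3)nn2)cc1` carries a methoxyphenyl on one side of the shared core and a 3,4-dimethoxyphenyl on the other. In a functional assay on MCF7 cells (Homo sapiens) for antiproliferative activity, read by sulforhodamine B assay, with a stated time of 48 h (on this read-out lower numbers stand for stronger inhibition of growth and higher numbers for weaker inhibition of growth), compound 2 reaches only the limit of the assay, > 100000 nM. Compound 1 `COc1cc(Cn2cc(CNC(=O)c3cn(-c4ccccc4)nc3-c3ccccc3)nn2)cc(OC)c1OC`, which pairs a plain phenyl with the 3,4,5-trimethoxyphenyl group, likewise gives only the limit > 100000 nM in this assay. Both values shown sit at this limit (the limit of > 100000 nM in this assay, at which 2 of the 2 values shown sit). Compound 3 `COc1ccc(-c2nn(-c3ccccc3)cc2C(=O)NCc2cn(Cc3cc(OC)c(OC)c(OC)c3)nn2)cc1` differs from compound 2 by methoxy in place of hydrogen on an aromatic carbon, in words: methoxy in place of hydrogen on an aromatic carbon, so that the 3,4-dimethoxyphenyl becomes a 3,4,5-trimethoxyphenyl. Neither measured compound gives a number from which a step could be read. Compound 1 sits at the limit > 100000 nM although it already carries the 3,4,5-trimethoxyphenyl group. Compound 3 is therefore expected to remain at the limit as well, with a step that the limit leaves unreadable from compound 2 to compound 3 of no clear size or direction. The estimate for compound 3 is 150000 nM, within 50000 nM to 500000 nM.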

Compound 3, concentration for 50% growth inhibition: 7600 nM
Estimate against measurement, compound 3: 20-fold (1.30 log units) above; measured number outside the range, below it.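

In this assay, the third methoxy on the 3,4-dimethoxyphenyl proves decisive: the change to the 3,4,5-trimethoxyphenyl brings an at least 13-fold lower number from compound 2 to compound 3 (1.11 log units; beyond the scatter), and the same kind of change on the other side of the shared core, where a plain phenyl becomes a methoxyphenyl, brings an at least 13-fold lower number from compound 1 to compound 3 (1.11 log units; beyond the scatter). Among these three compounds, then, neither the methoxyphenyl nor the 3,4,5-trimethoxyphenyl alone yields a measurable value, and only the compound carrying both does. Both steps are minimum sizes rather than exact ones, since their starting points are limits and not numbers: the limit of > 100000 nM in this assay, at which 2 of the 3 values shown sit.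

As far as these compounds go, whether an ethoxy, a hydroxyl or a fluorine in place of the new methoxy would keep this growth inhibition remains open. So does the true size of either step.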